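Fluoro to chloro on the methoxy-bearing ring

This account rests on a few compounds, and the source may have more. Where it says the series, first, only, none or still open, it means among the compounds named here.

Among the compounds with values here, in a functional assay on A549 cells (Homo sapiens) for antiproliferative activity, read by MTT assay, with a stated time of 48 h (a lower number here means a stronger inhibitor, a higher number a weaker inhibitor), compound 1 (`COc1ccc(N(C)c2ccnc(Cl)n2)cc1`) gives 611 nM and compound 2 (`COc1ccc(N(C)c2ccnc(Cl)n2)cc1F`) gives 651 nM, so compound 2 stands within the scatter of its only measured neighbour. Compound 3 (`COc1ccc(N(C)c2ccnc(Cl)n2)cc1Cl`) carries chloro in place of fluoro on an aromatic carbon, ortho to a methoxy group (chloro in place of fluoro on an aromatic carbon) and otherwise matches compound 2. Within the data shown here, one measured step bears on this change, the fluoro in place of hydrogen at the same carbon: a 1.1-fold higher number from compound 1 to compound 2 (0.03 log units; within the scatter) is the whole of the evidence. Among the measured compounds shown here, no measured compound carries chloro, so this support is indirect. No step beyond the scatter is expected in this assay on this basis. The estimated step is a 1.1-fold lower number from compound 2 to compound 3 (0.02 log units; within the scatter) and no direction is favoured. For compound 3 the expected value is 620 nM with an estimated range of 300 nM to 1250 nM for repeat measurements.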

Compound 3, half-maximal inhibitory concentration: 621 nM
Compound 3: the middle estimate sits 1.0-fold (0.00 log units) below what was measured; the range from low to high includes it.
By their numbers in this assay, from the lowest: compounds 1, 3 and 2 (each within the scatter of the next).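

In this assay the carbon ortho to a methoxy group now carries a second halogen: chloro in place of fluoro gives a 1.0-fold lower number from compound 2 to compound 3 (0.02 log units; within the scatter) and chloro in place of hydrogen gives a 1.0-fold higher number from compound 1 to compound 3 (0.01 log units; within the scatter) as a direct reading for this change. Hydrogen, fluoro and chloro at this carbon are thus not separated by this read-out, where earlier only the hydrogen and fluoro pair could be compared. Nothing measured on hand accounts for this result.

Open, from the compounds shown here alone, is whether a group of another kind at this carbon, such as an amine, a nitrile or a longer alkoxy chain, would also stay within the scatter. Also open, going by these compounds, is whether chloro and fluoro stay level once the methoxy group is replaced by a hydroxyl group.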